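A few compounds are considered here, and "the series" means these few. Any claim that something is new, unique, unknown or untested is made for them only; others in the source may bear on it.

Of the compounds shown here, three built on one shared core have been tested in a functional assay on the whole organism (strain Wistar) for inhibition, with Rattus norvegicus as the target, read by paw edema, with stated times of 60 min and 4 h, at a dose of 100 mg/kg by the oral route; a lower number here means less inhibition, a higher number more inhibition at the dose given (going by the name of the read-out). Compound 1 `COc1cc2c(cc1OC)C(CC(N)=O)CC2` carries no substituent on its amide nitrogen; in this assay compound 1 gives 31.3%. Compound 2 `CNC(=O)CC1CCc2cc(OC)c(OC)cc21` carries a methyl on that nitrogen, and in this assay compound 2 gives 29.7%. Compound 3 `CCCNC(=O)CC1CCc2cc(OC)c(OC)cc21` carries a propyl there, and in this assay compound 3 gives 26.6%. On the bare numbers compound 2 falls between the other two, yet the step of a number 1.6 percentage points lower from compound 1 to compound 2 (within the scatter) and the step of a number 3.1 percentage points lower from compound 2 to compound 3 (within the scatter) both lie within the scatter, so no order among the three can be claimed.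

Compound 4 `COc1cc2c(cc1OC)C(CC(=O)NC(C)C)CC2` has not yet been measured. It differs from compound 2 in one place: isopropyl in place of methyl on an amide-type nitrogen. The measured steps that bear on this change are those that alter the group on the amide nitrogen: a number 1.6 percentage points lower from compound 1 to compound 2 (within the scatter), a number 4.7 percentage points lower from compound 1 to compound 3 (within the scatter) and a number 3.1 percentage points lower from compound 2 to compound 3 (within the scatter). Each of these is within the scatter, whether a methyl or a propyl replaces the hydrogen or an ethyl lengthens the methyl. The expected step is therefore a number 1.7 percentage points lower from compound 2 to compound 4 (within the scatter), nothing beyond the scatter. Compound 4 is accordingly estimated at 28%, with a range from 18% to 38%.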

Compound 4, a percentage reported as inhibition, in the whole organism at one dose (the size of the read-out at that dose, not a potency): 39.1%
Estimate against measurement, compound 4: 11.1 percentage points below; the measured number lies above the stated range.
By their numbers in this assay, from the lowest: compounds 3, 2, 1 and 4 (each within the scatter of the next, the first and the last beyond it).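

In this assay, the group on the amide nitrogen now gives its first step beyond the scatter: a number 12.5 percentage points higher from compound 3 to compound 4 (beyond the scatter), a modest step that swaps a propyl for an isopropyl, so the identity of the alkyl group can matter here, and not only whether one is present. This holds for that one pair alone, since a number 9.4 percentage points higher from compound 2 to compound 4 (within the scatter) and a number 7.8 percentage points higher from compound 1 to compound 4 (within the scatter), so isopropyl cannot be set apart from methyl or from the plain amide hydrogen. The data given offer no measurement that would explain why isopropyl and propyl part in this way.

Still open, from the compounds shown here alone, is whether the difference carries over to other groups on this nitrogen, such as a tert-butyl, a cyclopropyl or a longer chain like butyl, or to a carboxylic acid in place of the amide. Each number is also the size of the effect at a single dose, so these compounds leave unanswered how their potencies compare, and one pair is thin support for any rule about branched groups.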